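A few compounds are considered here, and "the series" means these few. Any claim that something is new, unique, unknown or untested is made for them only; others in the source may bear on it.

Measured compounds:
compound 1, `CC(C)(C)OC(=O)NCNC(=O)CN1CN(c2ccccc2)C2(CCN(C(=O)c3ccc(C4CCCCC4)cc3)CC2)C1=O`: 1700 nM
compound 2, `COC(=O)CCCNC(=O)CN1CN(c2ccccc2)C2(CCN(C(=O)c3ccc(C(C)(C)C)cc3)CC2)C1=O`: "not determined" (no result reported)

In an assay on HEK293 cells for displacement of a labelled ligand from NPC1-like intracellular cholesterol transporter 1 (Homo sapiens) (a lower number here means a stronger inhibitor, a higher number a weaker inhibitor), compound 1 gives 1700 nM. Going by the values given here, this is the only number in the set: compound 2 was entered in the same series but has no reported value, so compound 1 has no measured neighbour to stand against, and its place can only be described as the sole reference point.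

The step followed here leads from compound 1 to compound 3, `O=C(CN1CN(c2ccccc2)C2(CCN(C(=O)c3ccc(C4CCCCC4)cc3)CC2)C1=O)NCO`. The change is hydroxy in place of (tert-butoxycarbonyl)amino on a saturated chain carbon bound to an amide-type nitrogen. The (tert-butoxycarbonyl)amino group leaves and a single hydroxy takes its place on a saturated chain carbon bound to an amide-type nitrogen; the rest of the molecule, including the shared core and the cyclohexyl-bearing benzoyl piece, is untouched.

Among the compounds with values here, no measured pair shows what such a change does in this assay, so the expectation rests on compound 1 alone. A moderate step is expected, plausibly toward weaker binding, read as a 1.6-fold higher number from compound 1 to compound 3 (0.22 log units; within the scatter). Compound 3 is therefore estimated at 2800 nM, within a range from 800 nM to 9000 nM.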

Compound 3, half-maximal inhibitory concentration: 8300 nM
Beside the measured number, compound 3's estimate is 3.0-fold (0.47 log units) below it; measured number inside the range.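

In this assay, going by these compounds alone, the swap of (tert-butoxycarbonyl)amino for hydroxy on a saturated chain carbon bound to an amide-type nitrogen gives a 4.9-fold higher number from compound 1 to compound 3 (0.69 log units; beyond the scatter) and is the first measured change at this position in the set. It shows that the position is not indifferent to what it carries: compound 3, which has lost a group of 8 heavy atoms and gained a group of 1 heavy atom, binds more weakly than compound 1, and the small hydroxy does not hold the level of the larger group it replaces. Nothing available here accounts for the rise in the number, and this single pair cannot separate the effect of the lost atoms from that of the new hydroxy.

The compounds shown leave open whether the number depends on the size of the group at this place or on its kind, a question that a plain amine, a carboxylic acid or a longer chain ending in a methoxy group at the same chain carbon could help to settle. They also leave open whether the same swap would carry the same step with a group other than the cyclohexyl on the benzoyl piece, such as the tert-butyl seen in compound 2, which has no reported value.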